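Hydroxypiperidinylmethyl in Place of the Tertiary Alcohol

The source may hold more compounds than are shown below. What is called first, only, known or untested is meant among the compounds shown, and "the series" means these compounds.

The measured compounds:
Compound 1 `Fc1ccc(-c2cn(-c3ccnc4cc(Cl)ccc34)nn2)cc1` gives > 3080000 nM in an ADME assay on HepG2 cells (Homo sapiens) for cytotoxicity, read by MTT assay, with a stated time of 24 h; a lower number here means that less compound is tolerated, a higher number that more compound is tolerated; this is a limit of the assay, not a number.
Compound 2 `CC(C)(O)c1cn(-c2ccnc3cc(Cl)ccc23)nn1` gives 442000 nM in this assay.
Compound 3 `O=C(OCc1cn(-c2ccnc3cc(Cl)ccc23)nn1)c1ccc(Cl)cc1` gives 484000 nM in this assay.

Compound 2 and compound 3 lie within the usual scatter of each other, so no order between them can be read. Compound 1 stands apart in that its result is a limit (the limit of > 3080000 nM in this assay, at which 1 of the 3 values shown sits). Among the compounds with values here, the only step between measured compounds is an at least 6.9-fold lower number from compound 1 to compound 2 (0.84 log units; beyond the scatter), and since compound 1 sits at the limit, only its least size is known.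

Compound 4 `OC1CCN(Cc2cn(-c3ccnc4cc(Cl)ccc34)nn2)CC1` is the unmeasured analogue. It differs from compound 2 by (4-hydroxypiperidin-1-yl)methyl in place of 1-hydroxy-1-methylethyl on an aromatic carbon. Within the data shown here, no measured step exchanges one substituent for another of this kind on the shared core, so the step from compound 1 to compound 2 bears on it only loosely: it shows that a change at this carbon can move the number beyond the scatter, but nothing shows the direction for this particular exchange. Compound 4 is therefore expected to stay near compound 2, with a 1.1-fold higher number from compound 2 to compound 4 (0.05 log units; within the scatter) taken as no step beyond the scatter. The estimate for compound 4 in this assay is 500000 nM, in the range from 150000 nM to 3000000 nM.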

Compound 4, half-maximal cytotoxic concentration: 930000 nM
The estimate for compound 4 lay 1.9-fold (0.27 log units) below the measured number; the measured number falls inside the stated range.
By their numbers in this assay, from the lowest: compounds 2, 3 and 4 (each within the scatter of the next, the first and the last beyond it). At a limit, above all of these: compound 1.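

At this aromatic carbon of the five-membered ring, (4-hydroxypiperidin-1-yl)methyl in place of 1-hydroxy-1-methylethyl gives a 2.1-fold higher number from compound 2 to compound 4 (0.32 log units; beyond the scatter) in this assay, so a group carrying a six-membered non-aromatic ring with 1 hetero atom is tolerated here at a modestly higher number than the tertiary alcohol. Set against 4-fluorophenyl at the same carbon, the same group gives an at least 3.3-fold lower number from compound 1 to compound 4 (0.52 log units; beyond the scatter), so a second non-aryl group on the shared core also stands lower than the aryl compound, in the same direction as the earlier step. Only the least size of that step is known, because compound 1 stands at a limit of the assay and not at a number: the limit of > 3080000 nM in this assay, at which 1 of the 4 values shown sits.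

The compounds shown leave open which part of the entering group goes with the higher number, the ring, its nitrogen or its hydroxyl, and a plain piperidin-1-ylmethyl group or an open-chain dimethylaminomethyl group would begin to separate these. They also leave open how a morpholin-4-ylmethyl group or a carboxylic acid at this carbon would read in this assay.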